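The source may hold more compounds than are shown below. What is called first, only, known or untested is meant among the compounds shown, and "the series" means these compounds.

Measured compounds in the series:
- compound 1, `CC(=O)N[C@@H](C)C(=O)N(C)/N=N/c1ccc(C(N)=O)cc1`: 18.4 h
- compound 2, `CCC(=O)N[C@@H](C)C(=O)N(C)/N=N/c1ccc(C#N)cc1`: 10.1 h
- compound 3, `CC(=O)NCC(=O)N(C)/N=N/c1ccc(C#N)cc1`: 7.6 h

These numbers come from a physicochemical assay for metabolic stability, read by HPLC, in phosphate buffer, at pH 7.7; on this read-out higher numbers stand for a longer-lived compound and lower numbers for a shorter-lived compound. On that read-out compound 3 sits at the low end of the three: compound 2 is nearest to it, and the gap to compound 1 is the widest of the set, beyond the scatter. Compound 4, `CC(=O)N[C@@H](C)C(=O)N(C)/N=N/c1ccc(C#N)cc1`, has not been run in this assay yet. It differs from compound 3 by methyl in place of hydrogen on a saturated chain carbon bound to an amide-type nitrogen and a carbonyl carbon.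

Within the data shown here, only one measured step touches this change, and not cleanly: a 1.3-fold lower number from compound 2 to compound 3 (0.12 log units; within the scatter) replaces the whole 1-acetamidoethyl-derived fragment in one move, so the loss of the methyl and the shortening of the acyl group are bundled together and the combined effect stayed within the scatter. Compound 1, which carries the methyl, gives 18.4 h, but its nitrile is replaced by a carboxamide, so it does not isolate the methyl either. Among the measured compounds shown here, with no step that separates the methyl from other changes, nothing in the data argues for a shift beyond the scatter. The step from compound 3 to compound 4 is therefore expected to be small, a 1.2-fold higher number from compound 3 to compound 4 (0.07 log units; within the scatter), pointing slightly upward toward the value of compound 2. Compound 4 is expected to give about 9 h, with a range of 5.5 h to 15 h.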

Compound 4, half-life: 9.8 h
Compound 4: middle estimate off by 1.1-fold (0.04 log units), on the low side; low and high end bracket the measured number.
By their numbers in this assay, from the lowest: compounds 3, 4, 2 and 1 (each within the scatter of the next, the first and the last beyond it).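

Among these compounds, compound 4 gives the first clean reading of this position in this assay: methyl in place of hydrogen on a saturated chain carbon bound to an amide-type nitrogen and a carbonyl carbon gives (a 1.3-fold higher number from compound 3 to compound 4 (0.11 log units; within the scatter)), so this single change stays inside the scatter. The compound also splits the two other differences into single-place steps, with the acyl change, hydrogen in place of methyl on a saturated chain carbon bound to a carbonyl carbon, reading (a 1.0-fold lower number from compound 2 to compound 4 (0.01 log units; within the scatter)) and cyano in place of carbamoyl on an aromatic carbon reading (a 1.9-fold lower number from compound 1 to compound 4 (0.27 log units; within the scatter)), and each of these also lies within the scatter. The notes hold no supporting data that would account for the size of any of these steps.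

From the compounds shown here alone, whether a longer chain such as ethyl, a hydroxymethyl group or the opposite configuration at the saturated chain carbon would stay within the scatter remains open. Going by these compounds, at the aromatic carbon, the effect of a carboxylic acid or an amine in place of cyano is equally open.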